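Chloro in place of nitro: compound 3 to compound 4

A few compounds are considered here, and "the series" means these few. Any claim that something is new, unique, unknown or untested is made for them only; others in the source may bear on it.

Compound 3 `CCOC(=O)C1=Cc2ccccc2OC1(OCc1cn(-c2ccc(F)c([N+](=O)[O-])c2)nn1)C(F)(F)F` gives 11900 nM in a functional assay on A549 cells (Homo sapiens) for inhibition, read by MTT assay, with a stated time of 24 h (a lower number here means a stronger inhibitor, a higher number a weaker inhibitor), the lowest of the two numbers shown. Compound 1 `CCOC(=O)C1=Cc2ccccc2OC1(OCc1cn(CC(=O)Nc2cccc(Cl)c2)nn1)C(F)(F)F` gives 12800 nM in this assay, and the step of a 1.1-fold lower number from compound 1 to compound 3 (0.03 log units; within the scatter) is within the scatter. Compound 2 `CCOC(=O)C1=Cc2ccccc2OC1(OCc1cn(-c2cccc(OC)c2)nn1)C(F)(F)F` reaches only a limit of this assay, > 150000 nM. The step of an at least 12-fold lower number from compound 2 to compound 3 (1.10 log units; beyond the scatter) is large, the one clear difference in the set, with one value sitting at the limit (the limit of > 150000 nM in this assay, at which 1 of the 3 values shown sits).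

Compound 4 `CCOC(=O)C1=Cc2ccccc2OC1(OCc1cn(-c2ccc(F)c(Cl)c2)nn1)C(F)(F)F` differs from compound 3 by chloro in place of nitro on an aromatic carbon. The measured steps of an at least 11-fold higher number from compound 1 to compound 2 (1.06 log units; beyond the scatter), a 1.1-fold lower number from compound 1 to compound 3 (0.03 log units; within the scatter) and an at least 12-fold lower number from compound 2 to compound 3 (1.10 log units; beyond the scatter) each replace the whole group on the aromatic nitrogen; none exchanges a single substituent on the six-membered aromatic ring of carbon only, so none bears directly on a chloro-for-nitro exchange. Going by the values given here, the expected step of a 1.0-fold higher number from compound 3 to compound 4 (0.00 log units; within the scatter) is therefore small, within the scatter, with a wide range since no measured step isolates this change. Compound 4 is expected to give 12000 nM in this assay, between 4000 nM and 40000 nM.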

Compound 4, half-maximal inhibitory concentration: 26300 nM
Beside the measured number, compound 4's estimate is 2.2-fold (0.34 log units) below it, and the stated range covers the measured number.
By their numbers in this assay, from the lowest: compounds 3 and 1 (each within the scatter of the next); then compound 4. At a limit, above all of these: compound 2.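

Unlike the earlier steps, which replace the whole group on the aromatic nitrogen, a 2.2-fold higher number from compound 3 to compound 4 (0.34 log units; beyond the scatter) changes a single substituent on the ring, ortho to a fluoro group, and even this modest step lies beyond the scatter. The 3-chloro-4-fluorophenyl group also trails the ((3-chlorophenyl)carbamoyl)methyl group, a 2.1-fold higher number from compound 1 to compound 4 (0.31 log units; beyond the scatter), but it remains well ahead of 3-methoxyphenyl, an at least 5.7-fold lower number from compound 2 to compound 4 (0.75 log units; beyond the scatter). Compound 2 stands at a limit, so that last step is only a bound: the limit of > 150000 nM in this assay, at which 1 of the 4 values shown sits.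

At this position the compounds shown compare only nitro and chloro, so an amine, a carboxylic acid or a nitrile there remains open. Also open, from the compounds shown here alone, is whether the chloro-for-nitro step keeps its size once the fluoro group is replaced by hydrogen.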